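Lipophilicity of compound 4: a small aryl exchange

The source may hold more compounds than are shown below. What is called first, only, known or untested is meant among the compounds shown, and "the series" means these compounds.

Measured in a physicochemical assay for lipophilicity; on this read-out higher numbers stand for higher lipophilicity and lower numbers for lower lipophilicity:
- compound 1 `C[C@H]1CC[C@@H]2[C@@H](OC(=O)[C@]23CC(c2ccc(Br)cc2)N(c2ccccc2)O3)[C@]2(C)C(=O)C=C[C@@]12O`: 4
- compound 2 `Cc1ccc(C2C[C@@]3(ON2c2ccccc2)C(=O)O[C@@H]2[C@H]3CC[C@H](C)[C@]3(O)C=CC(=O)[C@@]23C)cc1`: 3.64
- compound 3 `C[C@H]1CC[C@@H]2[C@@H](OC(=O)[C@]23CC(c2c(F)cccc2F)N(c2ccccc2)O3)[C@]2(C)C(=O)C=C[C@@]12O`: 3.42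

Compound 3 stands within the scatter of compound 2 and clearly under compound 1. Compound 4 `C[C@H]1CC[C@@H]2[C@@H](OC(=O)[C@]23CC(c2cccc(F)c2)N(c2ccccc2)O3)[C@]2(C)C(=O)C=C[C@@]12O` has 3-fluorophenyl in place of 2,6-difluorophenyl on a saturated ring carbon. Within the data shown here, no measured step makes this exact exchange. The nearest are two other aryl exchanges on the same carbon. One gave a number 0.58 log units lower from compound 1 to compound 3 (beyond the scatter), a modest change, and the other gave a number 0.22 log units lower from compound 2 to compound 3 (within the scatter). On that evidence, no change beyond the scatter is expected in this assay. The expected step is a number 0.08 log units higher from compound 3 to compound 4 (within the scatter). For compound 4 the estimated value is 3.5, with an expected range of 3.2 to 3.8.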

Compound 4, partition coefficient: 3.35
For compound 4 the middle estimate is 0.15 log units above the measured one, within the range that was stated.
By their numbers in this assay, from the lowest: compounds 4, 3 and 2 (each within the scatter of the next); then compound 1.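

In this assay the exchange of 2,6-difluorophenyl for 3-fluorophenyl on this saturated ring carbon gives a number 0.07 log units lower from compound 3 to compound 4 (within the scatter) and so leaves the two fluorinated compounds unresolved on this read-out. The exchange from 4-methylphenyl gives a number 0.29 log units lower from compound 2 to compound 4 (within the scatter) while the exchange from 4-bromophenyl gives a number 0.65 log units lower from compound 1 to compound 4 (beyond the scatter) and so, among the four aryl groups shown, only compound 1 stands apart from the other three. Nothing available explains this separation. The compounds shown leave open how this assay responds at this carbon to an aryl ring carrying an amine or a carboxylic acid.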